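A few compounds are considered here, and "the series" means these few. Any claim that something is new, unique, unknown or untested is made for them only; others in the source may bear on it.

Compound 1 `O=C(Nc1ccc(Cl)c(-c2nnc3c(Cl)cccn23)c1)c1ccc(C(F)(F)F)cc1F` was measured in a functional assay on A549 cells (Homo sapiens) for antiproliferative activity, read by MTT assay, with a stated time of 72 h; a lower number here means a stronger inhibitor, a higher number a weaker inhibitor; compound 1 gives > 100000 nM, which is a limit of the assay rather than a number.
Compound 2 `CS(=O)(=O)c1ccc(C(=O)Nc2ccc(Cl)c(-c3nnc4c(Cl)cccn34)c2)cc1`; in this assay compound 2 gives > 100000 nM, again a limit.
Compound 3 `CS(=O)(=O)c1ccc(C(=O)Nc2ccc(Cl)c(-c3nnc4c(Cl)cccn34)c2)c(Cl)c1`; in this assay compound 3 gives > 100000 nM, also a limit.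

Compound 2 therefore stands only at a limit, and the same holds for every value shown: all sit at the limit of > 100000 nM in this assay, at which 3 of the 3 values shown sit. Among the compounds with values here, the one measured step, a step that the two limits leave unreadable from compound 2 to compound 3, joins two limits and so its size cannot be read.

Compound 4 `CS(=O)(=O)c1cccc(C(=O)Nc2ccc(Cl)c(-c3nnc4c(Cl)cccn34)c2)c1` differs from compound 2 by 3-(methylsulfonyl)phenyl in place of 4-(methylsulfonyl)phenyl on a carbonyl carbon. Within the data shown here, no measured step moves the methylsulfonyl group from one position on the ring to another, and the only step that exists is unreadable, so there is nothing to suggest that compound 4 should leave the limit. In this assay compound 4 is expected to give about 150000 nM, within a range from 40000 nM to 600000 nM. The step that the limit leaves unreadable from compound 2 to compound 4 is expected to show no change beyond the scatter.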

Compound 4, half-maximal inhibitory concentration: > 100000 nM
Compound 4: a limit, no number; the forecaster's own chance of this, stated with the estimate: 85%; the middle value is on the limit's open side.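

Compound 2 and compound 4 both sit at a limit of the assay rather than at a number, so no size can be read for the step between them: the limit of > 100000 nM in this assay, at which 4 of the 4 values shown sit.

The compounds shown leave open whether 3-(methylsulfonyl)phenyl and 4-(methylsulfonyl)phenyl differ in antiproliferative activity at all.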